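From a Hydroxymethylphenyl Arm to a Pyrimidinyl Arm

This account rests on a few compounds, and the source may have more. Where it says the series, first, only, none or still open, it means among the compounds named here.

Of the compounds shown here, three sharing one core have been measured in an assay on CHO cells for displacement of a labelled ligand from adenosine receptor A3 (Homo sapiens), read by scintillation counting, with a stated time of 60 min; a lower number here means a stronger inhibitor, a higher number a weaker inhibitor. Compound 1 `CNC(=O)[C@@]12C[C@@H]1[C@@H](n1cnc3c(NC)nc(C#Cc4ccc(OC)cc4)nc31)[C@H](O)[C@@H]2O` gives 0.63 nM. Compound 2 `CNC(=O)[C@@]12C[C@@H]1[C@@H](n1cnc3c(NC)nc(C#Cc4cccc(C(F)(F)F)c4)nc31)[C@H](O)[C@@H]2O` gives 3.39 nM. Compound 3 `CNC(=O)[C@@]12C[C@@H]1[C@@H](n1cnc3c(NC)nc(C#Cc4ccc(CO)cc4)nc31)[C@H](O)[C@@H]2O` gives 2.16 nM, the second highest of the three numbers; it sits within the scatter of compound 2, while a 3.4-fold higher number from compound 1 to compound 3 (0.54 log units; beyond the scatter). Compound 4 `CNC(=O)[C@@]12C[C@@H]1[C@@H](n1cnc3c(NC)nc(C#Cc4ncccn4)nc31)[C@H](O)[C@@H]2O` differs from compound 3 in one place: pyrimidin-2-yl in place of 4-(hydroxymethyl)phenyl on a triple-bonded carbon. For the measured compounds named here, the steps that bear on changing the group on the triple-bonded carbon are a 5.4-fold higher number from compound 1 to compound 2 (0.73 log units; beyond the scatter) and a 1.6-fold lower number from compound 2 to compound 3 (0.20 log units; within the scatter), so swapping this aromatic group has moved the number by modest amounts at most. A modest step toward a higher number is therefore expected, as a 2.3-fold higher number from compound 3 to compound 4 (0.36 log units; beyond the scatter). Compound 4 is estimated at 5 nM, within a range of 1.5 nM to 20 nM.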

Compound 4, inhibition constant: 1.97 nM
Estimate against measurement, compound 4: 2.5-fold (0.40 log units) above; measured number inside the range.
By their numbers in this assay, from the lowest: compound 1; then compounds 4, 3 and 2 (each within the scatter of the next).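

The ring on the triple-bonded carbon need not be carbon only: with pyrimidin-2-yl, a six-membered aromatic ring with 2 hetero atoms and 0 hydrogen-bond donors, the data show a 1.1-fold lower number from compound 3 to compound 4 (0.04 log units; within the scatter) and a 1.7-fold lower number from compound 2 to compound 4 (0.24 log units; within the scatter) and so do not separate it from either of those arms. For the compounds shown here, the 4-methoxyphenyl arm still stands apart, with a 3.1-fold higher number from compound 1 to compound 4 (0.50 log units; beyond the scatter) as the one step here beyond the scatter. Nothing measured here explains these numbers. Open, on these data alone, is how a phenyl ring carrying an amine or a carboxylic acid would read, and whether a methoxy group on the pyrimidin-2-yl ring would bring the number closer to that of compound 1.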